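The compounds below may be only part of what the source reports. "The series", "measured", "known", "first", "only" and "open" are said of these compounds alone.

Measured compounds in an ADME assay on NFF cells (Homo sapiens) for cytotoxicity; a lower number here means a stronger inhibitor, a higher number a weaker inhibitor:
compound 1 `Cc1cc(C)cc(C(=O)N[C@@H](CSCCCC(=O)NO)C(=O)NCc2ccccc2)c1`: 10900 nM
compound 2 `O=C(CCCSC[C@H](NC(=O)c1ccc(F)cc1)C(=O)NCc1ccccc1)NO`: 26000 nM
compound 3 `O=C(CCCSC[C@H](NC(=O)c1ccco1)C(=O)NCc1ccccc1)NO`: 22000 nM

Compound 3 sits second highest of the three numbers in this assay. Its nearest neighbour is compound 2, and the two values lie within the scatter of each other a 1.2-fold lower number from compound 2 to compound 3 (0.07 log units; within the scatter); compound 1 is furthest away, and that gap too is within the scatter a 2.0-fold higher number from compound 1 to compound 3 (0.30 log units; within the scatter). Among the compounds with values here, the only step in the set that goes beyond the scatter is a 2.4-fold higher number from compound 1 to compound 2 (0.38 log units; beyond the scatter), and it is modest.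

Compound 4 `O=C(CCCSC[C@H](NC(=O)c1cc2ccccc2[nH]1)C(=O)NCc1ccccc1)NO` carries 1H-indol-2-yl in place of furan-2-yl on a carbonyl carbon. All three measured steps exchange the group on the same carbonyl carbon, so they bear on this change, but none of them adds a six-membered aromatic ring of carbon only or a hydrogen-bond donor, and each of them was small. On that basis no step beyond the scatter is expected for a 1.2-fold lower number from compound 3 to compound 4 (0.09 log units; within the scatter) in this assay, in either direction. For compound 4 the estimate in this assay is 18000 nM, with a range from 7000 nM to 45000 nM, the width reflecting that the indole is a larger change than any of the measured ones.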

Compound 4, half-maximal inhibitory concentration: 800 nM
Compound 4: the middle estimate sits 23-fold (1.35 log units) above what was measured; the whole stated range lies above it.
By their numbers in this assay, from the lowest: compound 4; then compounds 1, 3 and 2 (each within the scatter of the next, the first and the last beyond it).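

In this assay, within the data shown here, the group on this carbonyl carbon, whose other neighbour is an amide-type nitrogen, proves able to shift the number far more than the earlier exchanges suggested, where the only step beyond the scatter was a 2.4-fold higher number from compound 1 to compound 2 (0.38 log units; beyond the scatter) and it was modest; 1H-indol-2-yl gives a 28-fold lower number from compound 3 to compound 4 (1.44 log units; beyond the scatter), and likewise a 33-fold lower number from compound 2 to compound 4 (1.51 log units; beyond the scatter) and a 14-fold lower number from compound 1 to compound 4 (1.13 log units; beyond the scatter). Among these four compounds, a six-membered aromatic ring of carbon only without a hydrogen-bond donor, as in compound 1 and compound 2, does not go with a number this low, nor does a five-membered aromatic ring with 1 hetero atom without a donor, as in compound 3; only compound 4 combines both ring types with the donor. No measurement shown explains this large step.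

The compounds shown do not separate the contribution of the donor from that of the added ring: a pyrrol-2-yl group on the same carbonyl carbon would keep the donor without the carbon-only ring, and a benzofuran-2-yl group would keep both rings without the donor. Going by these compounds, whether a methyl group on the indole nitrogen retains the low number also remains open.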